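The source may hold more compounds than are shown below. What is called first, only, known or untested is meant among the compounds shown, and "the series" means these compounds.

Of the compounds shown here, two of a shared core have been tested in a functional assay for agonist activity at P2Y purinoceptor 2 (Homo sapiens), read by FLIPR; on this read-out lower numbers stand for an effect already at smaller amounts and higher numbers for an effect only at larger amounts of compound. Compound 1, `O=c1c2ccsc2ccn1[C@@H]1O[C@H](COP(=O)(O)OP(=O)(O)OP(=O)(O)O)[C@@H](O)[C@H]1O`, gives 30 nM in this assay. Compound 2, `Cc1ccc2ccn([C@@H]3O[C@H](COP(=O)(O)OP(=O)(O)OP(=O)(O)O)[C@@H](O)[C@H]3O)c(=O)c2c1`, gives 148 nM in this assay, the higher of the two numbers, and the gap between compound 2 and compound 1 lies beyond the usual scatter of repeated measurements.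

Compound 3, `N#Cc1ccc2ccn([C@@H]3O[C@H](COP(=O)(O)OP(=O)(O)OP(=O)(O)O)[C@@H](O)[C@H]3O)c(=O)c2c1`, has not yet been measured in this assay. It differs from compound 2 in one place: cyano in place of methyl on an aromatic carbon. Both groups are small and sit on the same carbon, and the rest of the molecule, including the triphosphate chain and the sugar, is unchanged. Within the data shown here, no measured pair here shows what such an exchange does on this core, so there is nothing to lean on beyond the two values above.

The step from compound 2 to compound 3 is therefore expected to be small, a 1.2-fold lower number from compound 2 to compound 3 (0.09 log units; within the scatter), in either direction or none beyond the scatter. For compound 3 the estimate in this assay is 120 nM, with a range from 30 nM to 500 nM.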

Compound 3, half-maximal effective concentration: 12 nM
Compound 3: middle estimate off by 10-fold (1.00 log units), on the high side; the measured number lies below the stated range.
By their numbers in this assay, from the lowest: compound 3; then compound 1; then compound 2.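

Exchanging methyl for cyano on this aromatic carbon gives, in this assay, a 12-fold lower number from compound 2 to compound 3 (1.09 log units; beyond the scatter). The earlier compounds shown here differ in more than one place, so they could not show that this single carbon, on a six-membered aromatic ring of carbon only, has such a strong hold on the read-out while the sugar and the triphosphate chain stay the same. Cyano brings a triple bond and a hydrogen-bond acceptor that methyl lacks, but nothing here shows whether either feature matters for this step, and no supporting measurement is available to explain it.

Going by these compounds, it remains open whether other groups on this carbon, such as an amine, a carboxylic acid or a longer chain, would give numbers closer to those of compound 3 or compound 2. On these data alone, it is also open whether cyano would have a comparable effect on a different carbon of the same ring, so this single pair cannot yet be called a pattern.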